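Swapping an Aryl Group on the Core: Permeability Outlook

This account rests on a few compounds, and the source may have more. Where it says the series, first, only, none or still open, it means among the compounds named here.

Measured so far:
compound 1, `COc1ccc(-c2ccc3c(NCCCNCc4cccc(OC)c4O)ccnc3c2)cc1`, with 237 10^-6 cm/s
compound 2, `COc1ccc(-c2ccc3c(NCCCNCc4ccco4)ccnc3c2)cc1`, with 237 10^-6 cm/s

In an ADME assay for permeability, using PAMPA, with a stated time of 30 min, at pH 7.4 (a higher number here means that the compound crosses the layer faster, a lower number that the compound crosses the layer more slowly), compound 1 gives 237 10^-6 cm/s and compound 2 gives 237 10^-6 cm/s. For the measured compounds named here, the step of no change at the digits printed from compound 1 to compound 2 (within the scatter) leaves the read-out where it was, so compound 1 stands level with compound 2, its only measured neighbour.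

Compound 3, `COc1cccc(CNCCCNc2ccnc3cc(Cc4ccc(C#N)cc4)ccc23)c1O`, is not yet measured. It differs from compound 1 in 4-cyanobenzyl in place of 4-methoxyphenyl on an aromatic carbon. Going by the values given here, the one measured step touched a saturated chain carbon bound to an amine nitrogen, a different part of the molecule, and was flat; no measured step bears on the aromatic carbon that changes here. With only a flat step elsewhere to go by, the expected step of a 1.1-fold lower number from compound 1 to compound 3 (0.03 log units; within the scatter) is small, with no direction beyond the scatter. Compound 3 is therefore estimated at 220 10^-6 cm/s, in a range from 110 10^-6 cm/s to 350 10^-6 cm/s.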

Compound 3, apparent permeability: 23 10^-6 cm/s
Beside the measured number, compound 3's estimate is 9.6-fold (0.98 log units) above it, and the stated range ends above it.
By their numbers in this assay, from the lowest: compound 3; then compounds 1 and 2 (each within the scatter of the next).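

The aromatic carbon that holds 4-methoxyphenyl in compound 1 matters in this assay: placing 4-cyanobenzyl there gives a 10-fold lower number from compound 1 to compound 3 (1.01 log units; beyond the scatter), whereas the earlier change on a saturated chain carbon bound to an amine nitrogen gave no change at the digits printed from compound 1 to compound 2 (within the scatter). This single step changes two things at once, replacing methoxy with a nitrile and phenyl with benzyl, so it cannot show which of them goes with the lower number. Nothing available here explains the drop.

4-Cyanophenyl and 4-methoxybenzyl at the same aromatic carbon would help to separate those two changes. From the compounds shown here alone, it also remains open whether a much smaller group there, such as a single fluorine atom or an amine, would give a similar result, and whether 4-cyanobenzyl would have the same effect alongside the furan-2-yl group of compound 2.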